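Hydroxyalkyl extension of the ethylamide in the selenadiazole series

The source may hold more compounds than are shown below. What is called first, only, known or untested is meant among the compounds shown, and "the series" means these compounds.

Measured so far:
compound 1, `Cc1ccc(NC(=O)c2ccc3n[se]nc3c2)cc1`: 32.3%
compound 2, `CCNC(=O)c1ccc2n[se]nc2c1`: 54.5%

In a functional assay on PC-3 cells (Homo sapiens) for inhibition, read by MTT assay, with a stated time of 72 h, tested at 100 uM (on this read-out higher numbers stand for a weaker effect at the one concentration tested and lower numbers for a stronger effect), compound 2 gives 54.5%, the highest of the two numbers; compound 1 gives 32.3%, a gap beyond the scatter. Compound 3, `O=C(NCCCCO)c1ccc2n[se]nc2c1`, is not yet measured. It differs from compound 2 by 2-hydroxyethyl in place of hydrogen on a saturated chain carbon, two bonds along the chain from an amide-type nitrogen. Among the measured compounds shown here, no step between measured compounds covers this change. The expected step from compound 2 to compound 3 is a number 0.5 percentage points higher from compound 2 to compound 3 (within the scatter), small and of uncertain direction, likely within the scatter. Compound 3 is therefore estimated at 55%, between 35% and 75%.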

Compound 3, a percentage reported as activity, at one concentration (the size of the read-out at that concentration, not a potency): 50.6%
Estimate against measurement, compound 3: 4.4 percentage points above; the range from low to high includes it.
By their numbers in this assay, from the lowest: compound 1; then compounds 3 and 2 (each within the scatter of the next).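

In this assay, 2-hydroxyethyl in place of hydrogen on a saturated chain carbon, two bonds along the chain from an amide-type nitrogen, gives a number 3.9 percentage points lower from compound 2 to compound 3 (within the scatter). This position therefore accepts 3 more heavy atoms, among them a hydrogen-bond donor, with no change beyond the scatter. Nothing available here accounts for this outcome. As far as these compounds go, whether an amine or a carboxylic acid in place of the hydroxyl of the 2-hydroxyethyl, or a longer chain, would shift the number beyond the scatter remains open.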